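The source may report more compounds than this note shows. Statements on the series, on what has been measured and on what is new or still open speak of the compounds shown alone.

Measured so far:
compound 1 `CCCCCCCCCCc1ccc(-c2noc(C3CNC3)n2)cc1` — 65%
compound 2 `CCCCCCCCCCc1ccc(-c2noc([C@H]3CCCN3)n2)cc1` — 12%

In an assay on HeLa cells for inhibition of sphingosine-1-phosphate transporter SPNS2 (Mus musculus), read by LC-MS, tested at 2 uM (on this read-out lower numbers stand for less inhibition and higher numbers for more inhibition at the one concentration tested (going by the name of the read-out)), compound 1 gives 65%, while compound 2 gives 12%. Compound 2 stands lowest of the two numbers, and its nearest neighbour, compound 1, lies beyond the scatter above it, as the step of a number 53 percentage points lower from compound 1 to compound 2 (beyond the scatter) shows. Compound 3 `CCCCCCCCCCc1ccc(-c2noc(C3CCNCC3)n2)cc1` has not yet been measured; it differs from compound 2 in one place only: piperidin-4-yl in place of pyrrolidin-2-yl on an aromatic carbon. Within the data shown here, the single measured step bearing on this change is a number 53 percentage points lower from compound 1 to compound 2 (beyond the scatter), which shows that exchanging the ring at this place of the shared core can move the read-out by a large amount, there downward. With compound 2 holding the lower of the two numbers, a step back upward is expected for compound 3, though with wide uncertainty. Compound 3 is therefore estimated at 45% in this assay, within 15% to 75%, an expected step of a number 33 percentage points higher from compound 2 to compound 3 (beyond the scatter).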

Compound 3, a percentage reported as inhibition, at one concentration (the size of the read-out at that concentration, not a potency): 66%
Beside the measured number, compound 3's estimate is 21 percentage points below it; measured number inside the range.
By their numbers in this assay, from the lowest: compound 2; then compounds 1 and 3 (each within the scatter of the next).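

In this assay, the step of a number 54 percentage points higher from compound 2 to compound 3 (beyond the scatter) shows that the low number of compound 2 is not a fixed feature of this position on the shared core, since a different ring here restores a high reading. The step of a number 1 percentage points higher from compound 1 to compound 3 (within the scatter) lies within the scatter, so azetidin-3-yl and piperidin-4-yl read alike, and among these three groups only pyrrolidin-2-yl goes with a low number. Nothing available explains why that group stands apart.

Pyrrolidin-2-yl alone carries a defined stereocentre, so the effects of the ring, its point of attachment and its stereochemistry cannot be separated, and the mirror-image form or a pyrrolidin-3-yl group would help to do so. As far as these compounds go, how a cyclohexyl ring or an open-chain amine would read at this position also stays open.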